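Alkyne aryl swap: from chlorophenyl to pyridinyl

The source may hold more compounds than are shown below. What is called first, only, known or untested is meant among the compounds shown, and "the series" means these compounds.

Notes on the series. The shared core is that of compound 1 `CC(C)N1CCc2nc(C#Cc3ccccc3)ccc2C1=O`; compound 2 `Cc1ccccc1C#Cc1ccc2c(n1)CCN(C(C)C)C2=O` and compound 3 `CC(C)N1CCc2nc(C#Cc3ccccc3Cl)ccc2C1=O` carry substituents on the aromatic ring at the far end of the alkyne. In a functional assay on HEK293 cells for negative allosteric modulation of metabotropic glutamate receptor 5 (Homo sapiens), read by FLIPR and calcium flux (a higher number here means a weaker inhibitor, a lower number a stronger inhibitor), compound 1 gives 706 nM, compound 2 gives 810 nM and compound 3 gives 2520 nM. Compound 3 stands at the highest number of the three, with a 3.6-fold higher number from compound 1 to compound 3 (0.55 log units; beyond the scatter) and a 3.1-fold higher number from compound 2 to compound 3 (0.49 log units; beyond the scatter); the other pair shows a 1.1-fold higher number from compound 1 to compound 2 (0.06 log units; within the scatter).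

Compound 4 `CC(C)N1CCc2nc(C#Cc3ccccn3)ccc2C1=O` differs from compound 3 by pyridin-2-yl in place of 2-chlorophenyl on a triple-bonded carbon. Going by the values given here, no measured step involves a pyridinyl group, so nothing bears directly on this change. What does bear on it is the removal of chloro: compound 3 is the weakest by a 3.6-fold higher number from compound 1 to compound 3 (0.55 log units; beyond the scatter), and taking the chloro away is expected to bring the number back toward the level of compound 1 at 706 nM. The ring nitrogen of compound 4 is an unknown, and the expectation therefore remains wide. For compound 4 the estimated value in this assay is 1000 nM, within 300 nM to 4000 nM, which would mean an expected 2.5-fold lower number from compound 3 to compound 4 (0.40 log units; beyond the scatter).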

Compound 4, half-maximal inhibitory concentration: 27 nM
Estimate against measurement, compound 4: 37-fold (1.57 log units) above, and the stated range ends above it.
By their numbers in this assay, from the lowest: compound 4; then compounds 1 and 2 (each within the scatter of the next); then compound 3.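

In this assay, this end of the alkyne responds far more to a change of the ring itself than to the substituents seen so far: pyridin-2-yl in place of phenyl gives a 26-fold lower number from compound 1 to compound 4 (1.42 log units; beyond the scatter), a large step, whereas methyl and chloro on the phenyl ring gave steps no larger than modest. The same large gain appears against both substituted rings, with a 30-fold lower number from compound 2 to compound 4 (1.48 log units; beyond the scatter) for 2-methylphenyl and a 93-fold lower number from compound 3 to compound 4 (1.97 log units; beyond the scatter) for 2-chlorophenyl, so the unsubstituted pyridin-2-yl ring outperforms all three carbon-only aryl rings shown. No measurement at hand accounts for the gain from this ring nitrogen.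

The compounds shown leave open whether the gain is particular to pyridin-2-yl or would carry over to other nitrogen-containing rings at this alkyne carbon, such as pyrimidinyl or thiazolyl. They also leave open whether methyl, chloro or fluoro on the pyridin-2-yl ring would follow the phenyl ring of compound 1, where methyl gave a 1.1-fold higher number from compound 1 to compound 2 (0.06 log units; within the scatter) and chloro gave a 3.6-fold higher number from compound 1 to compound 3 (0.55 log units; beyond the scatter).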